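The compounds below may be only part of what the source reports. "The series", "measured", "known", "first", "only" and "open" are said of these compounds alone.

Compound 1 `CCCn1c(=O)[nH]c2nc(-c3ccc(S(=O)(=O)N4CCN(Cc5cccc(C)c5)CC4)cc3)[nH]c2c1=O` gives > 1000 nM in an assay on CHO cells for displacement of a labelled ligand from adenosine receptor A3 (Homo sapiens), read by scintillation counting, with a stated time of 45 min, in the presence of a further agent that is not named here; on this read-out higher numbers stand for weaker inhibition and lower numbers for stronger inhibition.
Compound 2 `CCCn1c(=O)[nH]c2nc(-c3ccc(S(=O)(=O)N(C)C)cc3)[nH]c2c1=O` gives 1220 nM in this assay.
Compound 3 `CCCn1c(=O)[nH]c2nc(-c3ccc(S(=O)(=O)N4CCN(c5ccccc5C)CC4)cc3)[nH]c2c1=O` gives > 1000 nM in this assay.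

For compound 1 the value is a limit of the assay and not a number. The value of compound 3 is also such a limit, so both sit at the limit of > 1000 nM in this assay, at which 2 of the 3 values shown sit. Compound 2 gives a number. The step that the two limits leave unreadable from compound 1 to compound 3 therefore cannot be read.

Compound 4 `CCCn1c(=O)[nH]c2nc(-c3ccc(S(=O)(=O)N4CCN(Cc5cccc(Br)c5)CC4)cc3)[nH]c2c1=O` differs from compound 1 by bromo in place of methyl on an aromatic carbon. Going by the values given here, no measured step involves this change, and the only recorded step is unreadable, so the expectation rests on where compound 1 stands. Compound 4 is expected to stay weak, with the step that the limit leaves unreadable from compound 1 to compound 4 estimated as no larger than the usual scatter. Compound 4 is estimated at 2000 nM, between 700 nM and 8000 nM.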

Compound 4, inhibition constant: > 1000 nM
Compound 4 was reported as a limit; the forecaster's own chance of this, stated with the estimate: 60%; the middle value does not contradict the limit.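

The result for compound 4 is a limit of the assay and not a number, so its steps from compound 1 and from compound 3 cannot be read: the limit of > 1000 nM in this assay, at which 3 of the 4 values shown sit.

As far as these compounds go, whether 3-bromobenzyl and 3-methylbenzyl differ at all in this assay stays open.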